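A few compounds are considered here, and "the series" means these few. Any claim that something is new, unique, unknown or untested is made for them only; others in the source may bear on it.

Compound 2, with the structure `C#CCNC(=O)/C(C)=C(\C)c1ccc(OC)cc1`, stands at the top of the two numbers measured in a toxicity assay on the whole organism (strain Icem-CET (SPF Caw)) for cytotoxicity, with Mus musculus as the target; on this read-out higher numbers stand for an effect only at larger amounts of compound and lower numbers for an effect already at smaller amounts: compound 2 gives 400 mg/kg. Within the data shown here, its only neighbour is compound 1, with the structure `C#CCNC(=O)/C(C)=C(\C)c1ccc(C)cc1`, and in this assay compound 1 gives 200 mg/kg. Among the measured compounds shown here, the single measured step, a 2.0-fold higher number from compound 1 to compound 2 (0.30 log units; within the scatter), involves an exchange at the same aromatic carbon and does not rise above the ordinary spread between repeated measurements, so on the present numbers compound 1 and compound 2 cannot be placed in any order.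

Compound 3, with the structure `C#CCNC(=O)/C(C)=C(\C)c1ccc(Br)cc1`, is the next compound to be tested. It differs from compound 2 in one place: bromo in place of methoxy on an aromatic carbon. For the measured compounds named here, no measured step involves bromo, so the only guide is the step from compound 1 to compound 2, a 2.0-fold higher number from compound 1 to compound 2 (0.30 log units; within the scatter), which stayed within the scatter for a swap at this same aromatic carbon. The expectation for compound 3 is therefore a step of about a 1.3-fold lower number from compound 2 to compound 3 (0.12 log units; within the scatter), not beyond the scatter. Compound 3 is estimated at 300 mg/kg, within a range from 150 mg/kg to 600 mg/kg.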

Compound 3, dose for half-maximal effect: 500 mg/kg
Estimate against measurement, compound 3: 1.7-fold (0.22 log units) below; measured number inside the range.
By their numbers in this assay, from the lowest: compounds 1, 2 and 3 (each within the scatter of the next, the first and the last beyond it).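

Bromo in place of methyl gives a 2.5-fold higher number from compound 1 to compound 3 (0.40 log units; beyond the scatter) in this assay and so offers the first sign, a modest one, that the group on this aromatic carbon can matter at all. Bromo in place of methoxy gives only a 1.3-fold higher number from compound 2 to compound 3 (0.10 log units; within the scatter) and leaves compound 2 and compound 3 in no order, even though this swap takes out 2 heavy atoms with 1 hydrogen-bond acceptor and puts in 1 heavy atom with none, so compound 2 lies within the scatter of both other compounds and the three do not fall into separate groups. Nothing available here bears on why the numbers fall as they do.

The compounds shown leave open how an amine, a carboxylic acid or a longer chain on this same aromatic carbon would read in this whole-animal test, and whether chloro or fluoro would fall close to bromo. They also leave open whether the modest step seen with bromo would hold if the rest of the shared core were changed, for example if the amide hydrogen were replaced by a methyl group.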